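This account rests on a few compounds, and the source may have more. Where it says the series, first, only, none or still open, it means among the compounds named here.

Three compounds that share one core have entries in an ADME assay on microsomes from liver (Mus musculus) for metabolic stability, with a stated time of 10 min; on this read-out higher numbers stand for a more stable compound and lower numbers for a less stable compound. Compound 1 `O=C([C@H]1CC[C@H](CO)CC1)N1CC[C@](c2ccc(C(F)(C(F)(F)F)C(F)(F)F)cc2)(S(=O)(=O)c2ccc(F)cc2)C1` gives 63%, and compound 2 `O=C(C1CCS(=O)(=O)C1)N1CC[C@](c2ccc(C(F)(C(F)(F)F)C(F)(F)F)cc2)(S(=O)(=O)c2ccc(F)cc2)C1`, measured twice, gives 78%; 96% (2 entries). Those two readings of compound 2 alone show how far apart repeat entries can fall. On these data alone, compound 3 `CC1(C(=O)N2CC[C@](c3ccc(C(F)(C(F)(F)F)C(F)(F)F)cc3)(S(=O)(=O)c3ccc(F)cc3)C2)CCS(=O)(=O)CC1` offers no number to start from, since its entry in this assay reads "not determined" (no result reported), so its place among the others remains open.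

The next compound, compound 4 `CCC1(C(=O)N2CC[C@](c3ccc(C(F)(C(F)(F)F)C(F)(F)F)cc3)(S(=O)(=O)c3ccc(F)cc3)C2)CCS(=O)(=O)CC1`, has yet to be measured. The structural change is methyl in place of hydrogen on a saturated chain carbon bound to a saturated ring carbon. In words, this is methyl in place of hydrogen on a saturated chain carbon bound to a saturated ring carbon, which turns 4-methyl-1,1-dioxothian-4-yl into 4-ethyl-1,1-dioxothian-4-yl. Among the compounds with values here, no measured pair in this set tests such a change, so the step is expected to stay within the usual scatter of this assay, with no firm direction. The expectation therefore has to lean on the neighbours, compound 1 at 63% and compound 2 at 78%; 96% (2 entries), and the wide spread of these values argues for a broad range. In this assay the estimate for compound 4 is 74%, expected to lie between 50% and 94%.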

Compound 4, percent of the compound remaining: 0%
The estimate for compound 4 lay 74 percentage points above the measured number, outside the stated range (below it).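

Replacing 4-(hydroxymethyl)cyclohexyl with 4-ethyl-1,1-dioxothian-4-yl on a carbonyl carbon gives, in this assay, a number 63 percentage points lower from compound 1 to compound 4 (beyond the scatter). The group on this carbonyl carbon can therefore take the read-out down to nothing on the shared core, something the readings of compound 1 at 63% and compound 2 at 78%; 96% (2 entries) gave no sign of. This drop is also much wider than the gap between repeat readings of a single compound, so the spread of repeats does not account for it: the several entries of compound 2 in this assay, 78%; 96% (2 entries)

On these data alone, the step from compound 3 to compound 4 cannot be read, since compound 3 has no number, so it stays open whether methyl in place of hydrogen on a saturated chain carbon bound to a saturated ring carbon causes the loss, or whether the 4-methyl-1,1-dioxothian-4-yl group would already read as low. The compounds shown also leave open how a propyl chain, an amine or a carboxylic acid in place of the ethyl would read in this assay.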